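Methoxy for Chloro on the Sulfonamide Aryl Ring

This account rests on a few compounds, and the source may have more. Where it says the series, first, only, none or still open, it means among the compounds named here.

Within the data shown here, the three compounds measured so far share one core and differ only in the aryl group on the sulfonamide nitrogen. Compound 1 `O=S(=O)(Nc1ccccc1Cl)c1ccc(-c2cnc(C3CC3)o2)cc1` carries a 2-chlorophenyl group, and in a functional assay on cells (leukaemia cell line, Homo sapiens) for inhibition, read by sulforhodamine B assay, with a stated time of 48 h (on this read-out higher numbers stand for lower toxicity in this test and lower numbers for higher toxicity in this test), compound 1 reaches only the limit of > 100000 nM. Compound 2 `O=S(=O)(Nc1ccc(F)c(Cl)c1)c1ccc(-c2cnc(C3CC3)o2)cc1` carries a 3-chloro-4-fluorophenyl group, and in this assay compound 2 likewise stops at the limit of > 100000 nM. Compound 3 `O=S(=O)(Nc1ccc(F)cc1F)c1ccc(-c2cnc(C3CC3)o2)cc1` carries a 2,4-difluorophenyl group, and in this assay compound 3 also gives the limit of > 100000 nM. The steps a step that the two limits leave unreadable from compound 1 to compound 2, a step that the two limits leave unreadable from compound 1 to compound 3 and a step that the two limits leave unreadable from compound 2 to compound 3 therefore cannot be sized, since (the limit of > 100000 nM in this assay, at which 3 of the 3 values shown sit). Compound 2 thus stands where every measured compound stands, at the limit, with nothing readable to set it apart. Compound 4 `COc1cc(NS(=O)(=O)c2ccc(-c3cnc(C4CC4)o3)cc2)ccc1F` differs from compound 2 by methoxy in place of chloro on an aromatic carbon. Among the measured compounds shown here, none of the measured steps bears on this exchange in a readable way, and none gives a direction. One therefore expects compound 4 to stay at the limit, a step that the limit leaves unreadable from compound 2 to compound 4 not beyond the scatter, with an estimate of 150000 nM spanning 40000 nM to 600000 nM.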

Compound 4, concentration lethal to 50% of the cells: > 100000 nM
Compound 4: a limit, no number; the forecaster's own chance of this, stated with the estimate: 80%; the middle value does not contradict the limit.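

Compound 4 ends at the same limit as compound 1, compound 2 and compound 3, so no step among these four compounds can be read: the limit of > 100000 nM in this assay, at which 4 of the 4 values shown sit.

The compounds shown leave open whether any of these aryl groups on the sulfonamide nitrogen changes the read-out in this assay, as none gives a number to compare.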